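The compounds below may be only part of what the source reports. "The series", "measured", "known", "first", "only" and "open" are said of these compounds alone.

Measured compounds:
- compound 1, `Nc1nc2c(c(-c3ccoc3)cn2[C@@H]2O[C@H](CO)[C@@H](O)[C@H]2O)c(=O)[nH]1`: > 15000 nM
- compound 2, `Nc1nc2c(c(-c3cc4ccccc4o3)cn2[C@@H]2O[C@H](CO)[C@@H](O)[C@H]2O)c(=O)[nH]1`: > 20000 nM
- compound 3, `Nc1nc(N)c2c(-c3ccoc3)cn([C@@H]3O[C@H](CO)[C@@H](O)[C@H]3O)c2n1`: > 20000 nM

The test used here is a functional assay on HL-60 cells (Homo sapiens) for antiproliferative activity, read by XTT assay, with a stated time of 72 h; on this read-out higher numbers stand for weaker inhibition and lower numbers for stronger inhibition. In it compound 1 reaches only a limit of the assay, > 15000 nM, and no number. Compound 2 likewise gives only a limit, > 20000 nM. Compound 3 also stops at a limit, > 20000 nM. Compound 2 differs from compound 1 by one change, (1-benzofuran-2-yl in place of furan-3-yl on an aromatic carbon), and the step is a step that the two limits leave unreadable from compound 1 to compound 2, since both ends are limits (the limit of > 15000 nM in this assay, at which 1 of the 3 values shown sits, (the limit of > 20000 nM in this assay, at which 2 of the 3 values shown sit)). How the core of compound 1 and the core of compound 3 differ is not broken down here.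

The compound still to be measured is compound 4, `Nc1nc(N)c2c(-c3cc4ccccc4o3)cn([C@@H]3O[C@H](CO)[C@@H](O)[C@H]3O)c2n1`. It arises from compound 3 by 1-benzofuran-2-yl in place of furan-3-yl on an aromatic carbon, and the place where the change sits is described in the same words as for the change from compound 1 to compound 2, so it is the same change made on the other core. Because the earlier step is a step that the two limits leave unreadable from compound 1 to compound 2 and gives no readable size, the step expected from compound 3 to compound 4 is taken to be small, a step that the limit leaves unreadable from compound 3 to compound 4. With compound 3 at a limit, compound 4 is expected to stay in the same inactive region, estimated at 30000 nM, with a range from 10000 nM to 100000 nM.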

Compound 4, half-maximal inhibitory concentration: > 15000 nM
Compound 4: only a limit was reported; the forecaster's own chance of this, stated with the estimate: 85%; the middle value lies beyond the limit too.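

In this assay, compound 3 and compound 4 each reach only a limit of the assay and give no number, and the step between them cannot be read. The compounds shown leave open whether 1-benzofuran-2-yl in place of furan-3-yl changes antiproliferative activity on either core, and how strong any of these four compounds really is.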